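Swapping a Tetrazole for a Carboxypyridine on the Aryl Arm

A few compounds are considered here, and "the series" means these few. Any claim that something is new, unique, unknown or untested is made for them only; others in the source may bear on it.

Measured compounds:
- compound 1, `CCC(C)(C)Cc1c[nH]c(CCc2ccc(-n3ncnn3)cc2)n1`: 422 nM
- compound 2, `CCC(C)(C)Cc1c[nH]c(CCc2ccc(-n3ccnn3)cc2)n1`: 641 nM
- compound 3, `CCC(C)(C)Cc1c[nH]c(CCc2ccc(-c3cnsc3)cc2)n1`: 44 nM

Three compounds share one core and differ only in the ring attached to the outer benzene. In a functional assay on HEK293 cells for agonist activity at Bombesin receptor subtype-3 (Homo sapiens), read by luminescence and calcium flux, with a stated time of 10 min (on this read-out lower numbers stand for an effect already at smaller amounts and higher numbers for an effect only at larger amounts of compound), compound 1 gives 422 nM, the second highest of the three numbers. Its nearest neighbour is compound 2, with a 1.5-fold higher number from compound 1 to compound 2 (0.18 log units; within the scatter), a step that says little. The clear gap is to compound 3, with a 9.6-fold lower number from compound 1 to compound 3 (0.98 log units; beyond the scatter); compound 2 shows the same direction, with a 15-fold lower number from compound 2 to compound 3 (1.16 log units; beyond the scatter).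

The new compound 4, `CCC(C)(C)Cc1c[nH]c(CCc2ccc(-c3cccnc3C(=O)O)cc2)n1`, changes compound 1 in one place: 2-carboxypyridin-3-yl in place of 2H-tetrazol-2-yl on an aromatic carbon. Going by the values given here, only the step from compound 1 to compound 3 resembles this change, as both replace the tetrazole with a ring joined through carbon, and there it lowered the number by a modest amount. Among the compounds with values here, a carboxylic acid, however, appears in none of the measured compounds, so its effect is unknown. Compound 4 is therefore expected to stay near compound 1, with a 1.1-fold lower number from compound 1 to compound 4 (0.02 log units; within the scatter), and its estimated value in this assay is 400 nM, within a wide range from 60 nM to 2500 nM.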

Compound 4, half-maximal effective concentration: 1260 nM
Compound 4: the middle estimate sits 3.2-fold (0.50 log units) below what was measured; measured number inside the range.
By their numbers in this assay, from the lowest: compound 3; then compounds 1, 2 and 4 (each within the scatter of the next, the first and the last beyond it).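

In this assay, joining a ring through carbon at this place on the outer benzene does not by itself bring the number down: 2-carboxypyridin-3-yl gives a 3.0-fold higher number from compound 1 to compound 4 (0.48 log units; beyond the scatter), the opposite direction to 1,2-thiazol-4-yl. The two carbon-joined rings are far apart, with a 29-fold higher number from compound 3 to compound 4 (1.46 log units; beyond the scatter), so the position clearly tells them apart, whereas a 2.0-fold higher number from compound 2 to compound 4 (0.29 log units; within the scatter) leaves compound 2 and compound 4 indistinguishable. Nothing at hand explains why 2-carboxypyridin-3-yl behaves this way.

Still open, going by these compounds, is whether the carboxylic acid or the pyridine ring carrying it accounts for the step from the tetrazole. A pyridine ring with no carboxylic acid, or a methyl ester or primary amide in place of the acid, would separate the two.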